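A few compounds are considered here, and "the series" means these few. Any claim that something is new, unique, unknown or untested is made for them only; others in the source may bear on it.

Measured so far in an assay on membranes from HEK293 cells for displacement of a labelled ligand from adenosine receptor A2b (Homo sapiens), read by scintillation counting, with a stated time of 30 min, tested at 1 uM; on this read-out lower numbers stand for less inhibition and higher numbers for more inhibition at the one concentration tested (going by the name of the read-out):
- compound 1, `CC1=C(C(=O)OC(C)C)[C@H](c2ccco2)NC(=S)N1`: 12%
- compound 2, `CC1=C(C(=O)OC(C)(C)C)C(c2ccco2)NC(=O)N1C`: 26%
- compound 3, `CC1=C(C(=O)OC(C)C)C(c2ccoc2)NC(=O)N1C`: 37%

Compound 3 gives the highest of the three numbers in this assay. Its nearest neighbour is compound 2, whose number is lower by a gap beyond the scatter; compound 1 lies furthest away, also beyond the scatter. Among the compounds with values here, compound 2 and compound 3 differ in more than one place, so no single structural step between measured compounds is available for this series.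

The next compound, compound 4, `CC1=C(C(=O)OC(C)(C)C)C(c2ccoc2)NC(=O)N1C`, is still to be measured in this assay. It differs from compound 3 in one place: methyl in place of hydrogen on a saturated chain carbon bound to an oxygen next to a carbonyl group and two saturated chain carbons. Cut one bond further out, this reads as isopropoxycarbonyl to tert-butoxycarbonyl. Compound 2 already carries the tert-butoxycarbonyl group, but with a different furan attachment, so its value in this assay cannot be read as a measure of this change alone.

Within the data shown here, with no measured step to lean on, the expectation for this assay is a step of a number 5 percentage points lower from compound 3 to compound 4 (within the scatter), within the scatter rather than beyond it. Compound 4 is estimated at 32%, with a range from 15% to 50%.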

Compound 4, a percentage reported as inhibition, at one concentration (the size of the read-out at that concentration, not a potency): 16%
For compound 4 the middle estimate is 16 percentage points above the measured one; low and high end bracket the measured number.
By their numbers in this assay, from the lowest: compounds 1, 4 and 2 (each within the scatter of the next, the first and the last beyond it); then compound 3.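

In this assay the series now has its first single-place reading at the ester: on the furan-3-yl compounds, isopropoxycarbonyl to tert-butoxycarbonyl, with methyl in place of hydrogen on the saturated chain carbon bound to the oxygen, gives a number 21 percentage points lower from compound 3 to compound 4 (beyond the scatter) and so shows that this one added methyl is enough to change the read-out beyond the usual scatter. Within the data shown here, with tert-butoxycarbonyl held fixed, furan-3-yl in place of furan-2-yl on a saturated ring carbon gives a number 10 percentage points lower from compound 2 to compound 4 (within the scatter) and so does not separate these two compounds, which leaves the ester change as the only single-place step here that registers in this assay. Nothing measured here bears on why the added methyl has this effect.

Going by these compounds, whether the step from isopropoxycarbonyl to tert-butoxycarbonyl carries over to furan-2-yl compounds or to the core of compound 1 remains open, since one pair carries this reading. Also open, on these data alone, is how a methoxycarbonyl or ethoxycarbonyl group, a carboxylic acid or a primary amide would read in place of these esters.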